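A few compounds are considered here, and "the series" means these few. Any claim that something is new, unique, unknown or untested is made for them only; others in the source may bear on it.

Measured compounds in a functional assay on HL-60 cells (Homo sapiens), read by calcium flux; on this read-out lower numbers stand for an effect already at smaller amounts and higher numbers for an effect only at larger amounts of compound:
compound 1 `Cc1cc(Cc2ccc(C(F)(F)F)cc2)c(=O)n(CC(=O)Nc2ccc(Br)cc2)n1` gives > 50000 nM, a limit of the assay rather than a number.
compound 2 `Cc1cc(Cc2ccsc2)c(=O)n(CC(=O)Nc2ccc(Br)cc2)n1` gives > 50000 nM, likewise a limit.
compound 3 `Cc1cc(Cc2ccc(C(N)=O)cc2)c(=O)n(CC(=O)Nc2ccc(Br)cc2)n1` gives > 50000 nM, again a limit.

Compound 3 thus stands nowhere distinguishable from the other two: all three values sit at the limit of > 50000 nM in this assay, at which 3 of the 3 values shown sit. The three single-site steps a step that the two limits leave unreadable from compound 1 to compound 2, a step that the two limits leave unreadable from compound 1 to compound 3 and a step that the two limits leave unreadable from compound 2 to compound 3 are all of unreadable size, so no direction can be read from any of them in this assay.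

Compound 4 `Cc1cc(Cc2ccc(C#N)cc2)c(=O)n(CC(=O)Nc2ccc(Br)cc2)n1` differs from compound 3 by cyano in place of carbamoyl on an aromatic carbon. Within the data shown here, the only measured step that touches the same aromatic carbon is the unreadable one from compound 1 to compound 3, which gives no guidance on size or direction. With every value of the series at the limit, the expectation for compound 4 in this assay is that it remains there as well, the estimated step that the limit leaves unreadable from compound 3 to compound 4 being unreadable in the same way. Compound 4 is therefore estimated at 60000 nM, with a range of 15000 nM to 250000 nM.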

Compound 4, half-maximal effective concentration: > 50000 nM
Compound 4 was reported as a limit; the forecaster's own chance of this, stated with the estimate: 85%; the middle value lies beyond the limit too.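

In this assay, the steps from compound 1, compound 2 and compound 3 to compound 4 cannot be read, as all four values are limits: the limit of > 50000 nM in this assay, at which 4 of the 4 values shown sit. The compounds shown leave open whether any group at this place on the shared core gives a measurable value in this assay.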